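Notes on a thiazole-amide series: removing the pyrazole

The compounds below may be only part of what the source reports. "The series", "measured", "known", "first", "only" and "open" are said of these compounds alone.

Measured compounds:
compound 1 `Cc1ncn(-c2cc(NC(=O)c3ccc(C)c(Nc4nc(-c5cccnc5)cs4)c3)cc(C(F)(F)F)c2)n1`, 1630 nM
compound 2 `Cc1ccc(C(=O)Nc2cc(-c3cnn(C)c3)cc(C(F)(F)F)c2)cc1Nc1nc(-c2cccnc2)cs1`, 5380 nM

In a functional assay on K562 cells (Homo sapiens) for antiproliferative activity (a lower number here means a stronger inhibitor, a higher number a weaker inhibitor), compound 2 gives 5380 nM, the higher of the two numbers; compound 1 gives 1630 nM in this assay. Among the compounds with values here, the only step between measured compounds is a 3.3-fold higher number from compound 1 to compound 2 (0.52 log units; beyond the scatter), so the group on the trifluoromethyl-bearing ring is not without effect on the number.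

Compound 3 `Cc1ccc(C(=O)Nc2cccc(C(F)(F)F)c2)cc1Nc1nc(-c2cccnc2)cs1` carries hydrogen in place of 1-methyl-1H-pyrazol-4-yl on an aromatic carbon. Within the data shown here, no measured step removes this group outright; the one step that touches the same place swapped one five-membered heteroaryl for another and moved the number beyond the scatter. Taking the removal as at least as large a change, compound 3 is expected to give a number at or somewhat above that of compound 2, estimated as a 1.3-fold higher number from compound 2 to compound 3 (0.11 log units; within the scatter), with a wide range. The estimate for compound 3 is 7000 nM, between 2000 nM and 25000 nM.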

Compound 3, half-maximal inhibitory concentration: 1440 nM
Estimate against measurement, compound 3: 4.9-fold (0.69 log units) above; the whole stated range lies above it.
By their numbers in this assay, from the lowest: compounds 3 and 1 (each within the scatter of the next); then compound 2.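

In this assay, taking the 1-methyl-1H-pyrazol-4-yl off gives a 3.7-fold lower number from compound 2 to compound 3 (0.57 log units; beyond the scatter), so the higher number of compound 2 goes with that group, and a five-membered heteroaryl is not needed on this aromatic carbon, meta to a trifluoromethyl group, to hold the number of the series. Hydrogen in place of 3-methyl-1H-1,2,4-triazol-1-yl gives a 1.1-fold lower number from compound 1 to compound 3 (0.05 log units; within the scatter), which lies within the scatter, so among these three compounds only the pyrazole stands apart. Nothing measured here accounts for this difference.

Going by these compounds, it remains open whether the higher number of compound 2 comes from the pyrazole ring itself or from its methyl group, which the unmethylated 1H-pyrazol-4-yl would separate. On these data alone, it is also open where an amine such as dimethylamino or a carboxylic acid on this carbon would fall.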